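Replacing a methoxy group: what to expect for compound 4

This account rests on a few compounds, and the source may have more. Where it says the series, first, only, none or still open, it means among the compounds named here.

Compound 2 `CCc1cc(OC)c(S(C)(=O)=O)cc1C(=O)N=C(N)N` gives 30 nM in a functional assay for inhibition of sodium/hydrogen exchanger (Oryctolagus cuniculus); on this read-out lower numbers stand for stronger inhibition and higher numbers for weaker inhibition. Among the three measured compounds it stands second highest: compound 1 `COc1cc(C)c(C(=O)N=C(N)N)cc1S(C)(=O)=O` gives 16 nM, and the step of a 1.9-fold higher number from compound 1 to compound 2 (0.27 log units; within the scatter) lies within the scatter, whereas compound 3 `COc1ccc(C(=O)N=C(N)N)cc1S(C)(=O)=O` gives 270 nM, with the step of a 9.0-fold higher number from compound 2 to compound 3 (0.95 log units; beyond the scatter) lying beyond it. Compound 1 and compound 3 are separated by the largest step of the set, a 17-fold higher number from compound 1 to compound 3 (1.23 log units; beyond the scatter).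

Compound 4 `CCc1cc(Oc2cccnc2)c(S(C)(=O)=O)cc1C(=O)N=C(N)N` differs from compound 2 in a single place: pyridin-3-yl in place of methyl on an oxygen on an aromatic ring. Within the data shown here, none of the measured steps touches this oxygen. All three concern the group on the aromatic carbon, where a 1.9-fold higher number from compound 1 to compound 2 (0.27 log units; within the scatter) stays within the scatter while a 9.0-fold higher number from compound 2 to compound 3 (0.95 log units; beyond the scatter) and a 17-fold higher number from compound 1 to compound 3 (1.23 log units; beyond the scatter) go beyond it. The change leading to compound 4 therefore has no measured precedent among these compounds, and the three measurements give no direction for it. With nothing to point either way, the estimate for compound 4 is kept close to the number of compound 2 and given a wide range. Compound 4 is expected to give 40 nM, between 10 nM and 160 nM. The step of a 1.3-fold higher number from compound 2 to compound 4 (0.12 log units; within the scatter) is thus expected to remain within the scatter.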

Compound 4, half-maximal inhibitory concentration: 27 nM
Beside the measured number, compound 4's estimate is 1.5-fold (0.17 log units) above it; low and high end bracket the measured number.
By their numbers in this assay, from the lowest: compounds 1, 4 and 2 (each within the scatter of the next); then compound 3.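

Putting pyridin-3-yl in place of methyl on the oxygen gives a 1.1-fold lower number from compound 2 to compound 4 (0.05 log units; within the scatter) in this assay and so stays within the scatter. Among these compounds, this is the first reading at this oxygen, and it shows that a group of six heavy atoms, with a six-membered aromatic ring and a hydrogen-bond acceptor, can stand where a single carbon stood without a measurable shift in the number. The only step beyond the scatter that involves compound 2 remains the one at the aromatic carbon, a 9.0-fold higher number from compound 2 to compound 3 (0.95 log units; beyond the scatter), and nothing shown gives a reason why the number holds across the change at the oxygen.

The compounds shown carry only methyl and pyridin-3-yl on this oxygen, so it stays open whether a phenyl ring, which would lack the ring nitrogen, a pyridin-4-yl group, a longer chain or an amine would fit equally well. Going by these compounds, it also stays open whether pyridin-3-yl on the oxygen gives the same result with methyl rather than ethyl on the aromatic carbon, as in the core of compound 1.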